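Chloro in place of methyl on the aryl piperazine

A few compounds are considered here, and "the series" means these few. Any claim that something is new, unique, unknown or untested is made for them only; others in the source may bear on it.

Compound 3 `Cc1cccc(N2CCN(C(=O)C(C)N3C(=O)CC(C)C3=O)CC2)c1` carries a 3-methylphenyl group on its piperazine. In a functional assay on the whole organism (strain Swiss) with Mus musculus as the target, with a stated time of 0.25 h (a lower number here means that less compound is needed, a higher number that more compound is needed for the effect), compound 3 gives "not determined" (no result reported): the result was not determined, so there is nothing to place it against the two measured compounds. Those two are compound 1 `CC(C(=O)N1CCN(c2cccc(Cl)c2)CC1)N1C(=O)CC(C)(C)C1=O`, which in this assay gives 19.8 mg/kg, and compound 2 `CC1CC(=O)N(C(C)C(=O)N2CCN(c3cccc(C(F)(F)F)c3)CC2)C1=O`, which in this assay gives 24.6 mg/kg; these two values lie within the usual scatter of one another. Compound 4 `CC1CC(=O)N(C(C)C(=O)N2CCN(c3cccc(Cl)c3)CC2)C1=O` is the compound to be measured. The change from compound 3 to compound 4 is chloro in place of methyl on an aromatic carbon. Going by the values given here, with no measured step between a methyl and a chloro analogue here, no size or direction of step can be taken from the data; the best guide is that compound 4 carries the same chloro-substituted aryl piperazine as compound 1 and differs from it only in the imide ring. Compound 4 is therefore expected to come out near compound 1, at an estimated 22 mg/kg, with a likely range from 10 mg/kg to 48 mg/kg.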

Compound 4, dose for half-maximal effect: 13.6 mg/kg
For compound 4 the middle estimate is 1.6-fold (0.21 log units) above the measured one, and the stated range covers the measured number.
By their numbers in this assay, from the lowest: compounds 4, 1 and 2 (each within the scatter of the next).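

Compound 3 has no number in this assay, so the change from 3-methylphenyl to 3-chlorophenyl cannot be read. Compound 4 instead gives two other readable steps: a 1.8-fold lower number from compound 2 to compound 4 (0.26 log units; within the scatter) with chloro in place of trifluoromethyl on the aromatic carbon, and a 1.5-fold lower number from compound 1 to compound 4 (0.16 log units; within the scatter) with hydrogen in place of methyl on a saturated ring carbon, and neither step goes beyond the usual scatter of this measurement. No measurement offered here accounts for these results. The compounds shown leave open whether a methoxy group or an amine on the same aromatic carbon would give a step beyond the scatter. They also leave open whether a longer chain on the saturated ring carbon would shift the dose needed for the effect.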